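The source may report more compounds than this note shows. Statements on the series, on what has been measured and on what is new or still open speak of the compounds shown alone.

Within the data shown here, compound 2 `CC(=O)Nc1ccc(CN2CCN(CCCc3c[nH]c4ccc(-n5cnnc5)cc34)CC2)cc1` gives 6.1 nM in a functional assay on CHO cells for activation of 5-hydroxytryptamine receptor 1D (Homo sapiens), read by GTPgammaS binding (a lower number here means that less compound is needed, a higher number that more compound is needed for the effect), the highest of the two numbers known here; compound 1 `c1coc(CN2CCN(CCCc3c[nH]c4ccc(-n5cnnc5)cc34)CC2)c1` gives 0.5 nM. Among the measured compounds shown here, the only measured step at this position, a 12-fold higher number from compound 1 to compound 2 (1.09 log units; beyond the scatter), shows that the group on this carbon matters greatly. Compound 3 `c1ccc(CCCN2CCN(CCCc3c[nH]c4ccc(-n5cnnc5)cc34)CC2)cc1` differs from compound 2 by phenethyl in place of 4-acetamidophenyl on a saturated chain carbon bound to an amine nitrogen in a ring. For the measured compounds named here, no measured step matches this exact exchange, so the direction rests on the size of that one step alone. Compound 3 is therefore expected to show a modest shift toward a lower number, a 2.4-fold lower number from compound 2 to compound 3 (0.39 log units; beyond the scatter), with an estimated 2.5 nM and a range of 0.5 nM to 12 nM.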

Compound 3, half-maximal effective concentration: 4 nM
Compound 3: middle estimate off by 1.6-fold (0.20 log units), on the low side; low and high end bracket the measured number.
By their numbers in this assay, from the lowest: compound 1; then compounds 3 and 2 (each within the scatter of the next).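

In this assay the exchange of 4-acetamidophenyl for phenethyl (a 1.5-fold lower number from compound 2 to compound 3 (0.18 log units; within the scatter)) makes no difference that can be read, so at this position the acetamide is not needed to keep the number where compound 2 has it. The step of an 8.0-fold higher number from compound 1 to compound 3 (0.90 log units; beyond the scatter) leaves compound 1, with furan-2-yl, apart from both compounds that carry a six-membered aromatic ring. Nothing measured here explains this gap.

Going by these compounds, whether the low number is particular to furan-2-yl stays open. Thiophen-2-yl, pyridin-2-yl or plain phenyl on this carbon would test that.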